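Swapping a Saturated Ring for a Short Alkene

This account rests on a few compounds, and the source may have more. Where it says the series, first, only, none or still open, it means among the compounds named here.

Three compounds have been tested in a functional assay on MCF7 cells (Homo sapiens) for antiproliferative activity; on this read-out lower numbers stand for stronger inhibition and higher numbers for weaker inhibition:
compound 1 `COc1cc(Cc2nc3c(N)ncnc3n2CC2CCCO2)cc(OC)c1OC` gives 91200 nM
compound 2 `CCCCCn1c(Cc2cc(OC)c(OC)c(OC)c2)nc2c(N)nc(F)nc21` gives 36300 nM
compound 3 `COc1cc(Cc2nc3c(N)nc(F)nc3n2CCOC(C)C)cc(OC)c1OC` gives 15800 nM

Compound 1 stands highest of these three numbers: compound 2 lies below it and compound 3 lies lower still. Within the data shown here, the only step between compounds that differ in one place is a 2.3-fold lower number from compound 2 to compound 3 (0.36 log units; beyond the scatter), which concerns isopropoxy in place of propyl and so says little about a change of the present kind. Compound 4 `C/C=C/Cn1c(Cc2cc(OC)c(OC)c(OC)c2)nc2c(N)ncnc21` differs from compound 1 by prop-1-en-1-yl in place of oxolan-2-yl on a saturated chain carbon bound to an aromatic nitrogen. Among the measured compounds shown here, with no measured step that bears on this swap, no step beyond the scatter is expected: a 1.2-fold lower number from compound 1 to compound 4 (0.08 log units; within the scatter) is the estimate. Compound 4 is therefore expected to give about 75000 nM, within a range from 25000 nM to 220000 nM.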

Compound 4, half-maximal inhibitory concentration: 51300 nM
Compound 4: middle estimate off by 1.5-fold (0.16 log units), on the high side; measured number inside the range.
By their numbers in this assay, from the lowest: compound 3; then compounds 2, 4 and 1 (each within the scatter of the next, the first and the last beyond it).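

Replacing oxolan-2-yl with prop-1-en-1-yl on a saturated chain carbon bound to an aromatic nitrogen gives, in this assay, a 1.8-fold lower number from compound 1 to compound 4 (0.25 log units; within the scatter), so compound 1 and compound 4 cannot be told apart. At this position, then, the ring and its single hydrogen-bond acceptor can give way to an open chain with a double bond without a clear shift in the number. Nothing available explains why the two groups read alike. As far as these compounds go, whether an amine or a carboxylic acid on this chain carbon would move the number beyond the scatter remains open. So does whether this swap would read the same on the core of compound 3.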